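Replacing fluoro with cyclohexyl: from compound 2 to compound 3

The compounds below may be only part of what the source reports. "The series", "measured", "known", "first", "only" and "open" are said of these compounds alone.

Measured so far:
compound 1 `CS(=O)(=O)Nc1c(O)ccc2c1CCCC2c1c[nH]cn1`, 36.3 nM
compound 2 `CCS(=O)(=O)Nc1cc(F)cc2c1CCCC2c1c[nH]cn1`, 83.2 nM

In an assay on isolated protein for binding affinity to Alpha-1A adrenergic receptor (Rattus norvegicus), read by radioligand binding (on this read-out higher numbers stand for weaker inhibition and lower numbers for stronger inhibition), compound 2 has the higher of the two numbers, and its gap to compound 1 lies beyond the scatter. Compound 3 `CCS(=O)(=O)Nc1cc(C2CCCCC2)cc2c1CCCC2c1c[nH]cn1` is not yet measured. It differs from compound 2 by cyclohexyl in place of fluoro on an aromatic carbon. For the measured compounds named here, no measured pair shows a change of this kind, so the direction of the step is open. A modest increase in the number is expected, within wide bounds: a 1.8-fold higher number from compound 2 to compound 3 (0.26 log units; within the scatter). For compound 3 the estimate is 150 nM, in the range 30 nM to 700 nM.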

Compound 3, inhibition constant: 269 nM
Compound 3: middle estimate off by 1.8-fold (0.25 log units), on the low side; low and high end bracket the measured number.
By their numbers in this assay, from the lowest: compound 1; then compound 2; then compound 3.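

In this assay, for the compounds shown here, cyclohexyl in place of fluoro on the aromatic carbon para to a fused ring gives a 3.2-fold higher number from compound 2 to compound 3 (0.51 log units; beyond the scatter) and is the only change read at this position. Binding is weakened but not lost, since compound 3 still gives 269 nM in a measurable range. No available measurement bears on the cause of this step.

With only fluoro and cyclohexyl compared here, the position remains defined by two points. On these data alone, how a hydrogen, a methoxy group, an amine or a carboxylic acid would read at this carbon remains open.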